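A few compounds are considered here, and "the series" means these few. Any claim that something is new, unique, unknown or untested is made for them only; others in the source may bear on it.

Compound 1 `CN(Cc1cncnc1)S(=O)(=O)c1ccccc1Nc1cc(-c2ccc3ccn(C)c3c2)c2nccnc2c1` gives 62 nM.
Compound 2 `Cn1ccc2ccc(-c3cc(Nc4cnccc4C(=O)NC4CCNC(=O)C4)cc4nccnc34)cc21` gives 69 nM.

Both numbers come from an assay for inhibition of 6-phosphofructo-2-kinase/fructose-2,6-bisphosphatase 3 (Homo sapiens), read by ADP-Glo, with a stated time of 2 h; a lower number here means a stronger inhibitor, a higher number a weaker inhibitor. Compound 2 has the higher of the two, but its gap to compound 1 lies within the usual scatter, so the two compounds cannot be told apart on these readings. Compound 3 `CC(=O)N1CCC(NC(=O)c2ccncc2Nc2cc(-c3ccc4ccn(C)c4c3)c3nccnc3c2)C1` has not yet been measured in this assay. It differs from compound 2 in one place: 1-acetylpyrrolidin-3-yl in place of 2-oxopiperidin-4-yl on an amide-type nitrogen. Among the compounds with values here, no measured pair differs in just one place, so there is no earlier step to lean on. The step is expected to be small, a 1.4-fold higher number from compound 2 to compound 3 (0.16 log units; within the scatter), not clearly beyond the scatter. Compound 3 is therefore estimated at 100 nM, within 40 nM to 250 nM.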

Compound 3, half-maximal inhibitory concentration: 105 nM
The estimate for compound 3 lay 1.1-fold (0.02 log units) below the measured number; measured number inside the range.
By their numbers in this assay, from the lowest: compounds 1, 2 and 3 (each within the scatter of the next).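

In this assay, putting 1-acetylpyrrolidin-3-yl in place of 2-oxopiperidin-4-yl on the amide-type nitrogen gives a 1.5-fold higher number from compound 2 to compound 3 (0.18 log units; within the scatter) and so leaves the two compounds indistinguishable. This position therefore accepts a five-membered ring in place of a six-membered one, and a group with 0 hydrogen-bond donors in place of one with 1, without a clear difference in the reading. From the compounds shown here alone, whether a simple amine or a carboxylic acid on this nitrogen would read the same remains open. No measurement here explains the behaviour of either group.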